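This account rests on a few compounds, and the source may have more. Where it says the series, first, only, none or still open, it means among the compounds named here.

Measured so far in a functional assay on NCI-H460 cells (Homo sapiens) for inhibition, read by sulforhodamine B assay, with a stated time of 48 h; a higher number here means a weaker inhibitor of growth, a lower number a stronger inhibitor of growth:

compound 1, `CC1=CC[C@H](C(C)(C)NC(=S)N/N=C/c2ccccc2O)CC1`: 1900 nM
compound 3, `CC1=CC[C@H](C(C)(C)NC(=S)N/N=C/c2ccccc2[N+](=O)[O-])CC1`: 5000 nM
compound 2, `COc1cc(/C=N/NC(=S)NC(C)(C)[C@H]2CC=C(C)CC2)ccc1O`: reported only as a limit, > 100000 nM

Compound 1 holds the lowest of the two numbers in this assay. Its nearest neighbour is compound 3, and the change of nitro in place of hydroxy on the aromatic carbon gives a 2.6-fold higher number from compound 1 to compound 3 (0.42 log units; beyond the scatter), a modest shift to a higher number. Among the compounds with values here, for compound 2 the assay gives no number, only a limit (the limit of > 100000 nM in this assay, at which 1 of the 3 values shown sits), so it offers no scale for any step.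

Compound 4, `CC1=CC[C@H](C(C)(C)NC(=S)N/N=C/c2cccs2)CC1`, is the next compound to be run. Against compound 1 the difference is thiophen-2-yl in place of 2-hydroxyphenyl on a carbon with a double bond to nitrogen. Within the data shown here, no measured step replaces the whole aromatic ring in this way; the only step that touches the same ring is the one from compound 1 to compound 3, which changed a single substituent and moved the number modestly upward. The change to compound 4 is larger in kind, removing the hydroxy donor altogether and exchanging the six-membered ring for a five-membered one, so a shift of at least that order is expected, most likely toward a higher number in this assay.

Compound 4 is therefore estimated at 4500 nM, with a plausible range from 1500 nM to 15000 nM, corresponding to an expected step of a 2.4-fold higher number from compound 1 to compound 4 (0.37 log units; beyond the scatter).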

Compound 4, concentration for 50% growth inhibition: 10800 nM
Beside the measured number, compound 4's estimate is 2.4-fold (0.38 log units) below it, and the stated range covers the measured number.
By their numbers in this assay, from the lowest: compound 1; then compound 3; then compound 4. At a limit, above all of these: compound 2.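

In this assay, exchanging the whole aromatic group on the carbon with a double bond to nitrogen gives a 5.7-fold higher number from compound 1 to compound 4 (0.75 log units; beyond the scatter), so this position accepts a five-membered aromatic ring with a sulfur atom and still returns a measured number, though a higher one. With a 2.6-fold higher number from compound 1 to compound 3 (0.42 log units; beyond the scatter) also printed, both changes away from 2-hydroxyphenyl at this position lead to a higher number, and compound 1 keeps the lowest number among the compounds with a measured value; the nitro compound changes one substituent, whereas thiophen-2-yl alters ring size, the ring atoms and the hydrogen-bond donor count together, so this single step cannot be divided among those differences. Nothing shown here gives a reason for the step.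

Still open, on these data alone, is which of those differences carries the step, since an unsubstituted phenyl group on the same carbon would separate loss of the hydroxy from the change of ring. As far as these compounds go, it is also open whether the thiophen-2-yl result extends to a furan-2-yl group, or whether an amine on the six-membered ring could stand in for the hydroxy.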